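This account rests on a few compounds, and the source may have more. Where it says the series, first, only, none or still open, it means among the compounds named here.

Working notes on the series: in a functional assay on HeLa cells (Homo sapiens) for antiproliferative activity, read by MTT assay, with a stated time of 48 h (a lower number here means a stronger inhibitor, a higher number a weaker inhibitor), compound 1 (`COc1ccc2nc(NC(c3cn(-c4ccccc4)nc3-c3ccc([N+](=O)[O-])cc3)c3c(O)ccc4ccccc34)sc2c1`) gives 5540 nM and stands level, within the scatter, with compound 2 (`COc1ccc2nc(NC(c3cn(-c4ccccc4)nc3-c3cccc([N+](=O)[O-])c3)c3c(O)ccc4ccccc34)sc2c1`) at 6140 nM and compound 3 (`COc1ccc2nc(NC(c3cn(-c4ccccc4)nc3-c3cccc(I)c3)c3c(O)ccc4ccccc34)sc2c1`) at 6240 nM in the same read-out.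

Compound 4 (`O=[N+]([O-])c1ccc(-c2nn(-c3ccccc3)cc2C(Nc2nc3ccc(Cl)cc3s2)c2c(O)ccc3ccccc23)cc1`) carries chloro in place of methoxy on an aromatic carbon so that 6-methoxy-1,3-benzothiazol-2-yl becomes 6-chloro-1,3-benzothiazol-2-yl.

The measured steps are a 1.1-fold higher number from compound 1 to compound 2 (0.04 log units; within the scatter) and a 1.1-fold higher number from compound 1 to compound 3 (0.05 log units; within the scatter) and a 1.0-fold higher number from compound 2 to compound 3 (0.01 log units; within the scatter) and all lie within the scatter. They bear on this change only indirectly, since each alters the nitrophenyl or iodophenyl substituent and leaves the methoxy untouched. Among the measured compounds shown here, no measured compound carries chloro, and no measured step tests this position, so the data set no direction.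

Expected in this assay is no step beyond the scatter, an estimated 1.0-fold lower number from compound 1 to compound 4 (0.00 log units; within the scatter) with neither direction favoured. For compound 4 the estimate is 5500 nM with an expected range from 2200 nM to 13000 nM in this read-out.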

Compound 4, half-maximal inhibitory concentration: 13400 nM
Compound 4: middle estimate off by 2.4-fold (0.39 log units), on the low side; the whole stated range lies below it.
By their numbers in this assay, from the lowest: compounds 1, 2 and 3 (each within the scatter of the next); then compound 4.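

In this assay, among the compounds shown here, exchanging 6-methoxy-1,3-benzothiazol-2-yl for 6-chloro-1,3-benzothiazol-2-yl gives a 2.4-fold higher number from compound 1 to compound 4 (0.38 log units; beyond the scatter) and so moves the read-out beyond the scatter, which none of the earlier steps on the nitrophenyl or iodophenyl substituent did. For the compounds shown here, this is the first sign that the group on this aromatic carbon matters, with methoxy carrying the lower number and 4-nitrophenyl held constant, though the step is modest and rests on this one pair. Nothing available on the compounds accounts for the step, so no cause can be assigned to it.

As far as these compounds go, whether the same exchange gives a similar step with 3-nitrophenyl or 3-iodophenyl in place of 4-nitrophenyl remains open. Also open, from the compounds shown here alone, is how ethoxy, a dimethylamino group or a carboxylic acid at this place would compare with methoxy and chloro.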